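The source may hold more compounds than are shown below. What is called first, only, known or untested is meant among the compounds shown, and "the series" means these compounds.

Compound 1 `NC1=NC2(CCOCC2)N(OCCCOc2cccc(Cl)c2)C(N)=N1`: 150 nM
Compound 2 `Cc1ccc(OCCCON2C(N)=NC(N)=NC23CCOCC3)cc1`: 1060 nM

In a functional assay on A549 cells (Homo sapiens) for antiproliferative activity, read by MTT assay, with a stated time of 72 h (on this read-out higher numbers stand for weaker inhibition and lower numbers for stronger inhibition), compound 2 stands highest of the two numbers; its nearest neighbour, compound 1, gives 150 nM. For the measured compounds named here, the one step measured so far, a 7.1-fold higher number from compound 1 to compound 2 (0.85 log units; beyond the scatter), is a modest change and lies beyond the scatter.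

Compound 3 `NC1=NC2(CCOCC2)N(OCCCOc2ccccc2Br)C(N)=N1` is the next member. It differs from compound 2 as follows: 2-bromophenyl in place of 4-methylphenyl on an oxygen on a saturated carbon. The step from compound 1 to compound 2 is the only one that bears on this change, since it exchanged a halogen-bearing phenyl for 4-methylphenyl on the same oxygen, and the new compound reverses that exchange, though with bromine instead of chlorine and a different substitution pattern. A drop in the number is therefore expected for compound 3, estimated as a 3.5-fold lower number from compound 2 to compound 3 (0.55 log units; beyond the scatter). Compound 3 is expected at 300 nM, with a range of 80 nM to 1200 nM.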

Compound 3, half-maximal inhibitory concentration: 160 nM
Estimate against measurement, compound 3: 1.9-fold (0.27 log units) above; measured number inside the range.
By their numbers in this assay, from the lowest: compounds 1 and 3 (each within the scatter of the next); then compound 2.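

In this assay the change from 4-methylphenyl to 2-bromophenyl on an oxygen on a saturated carbon gives a 6.6-fold lower number from compound 2 to compound 3 (0.82 log units; beyond the scatter) and so shows that a second halogen-bearing phenyl, with a different halogen at a different ring position, also stands apart from compound 2. The comparison of the two halogen-bearing compounds gives a 1.1-fold higher number from compound 1 to compound 3 (0.03 log units; within the scatter), so 2-bromophenyl and 3-chlorophenyl cannot be told apart at this position, although the halogen and its ring position change together and their separate contributions cannot be read. Nothing available explains these differences in cellular activity.

Still open, from the compounds shown here alone, is whether the halogen itself matters or whether 4-methylphenyl alone stands out. Unsubstituted phenyl, 4-chlorophenyl, 2-chlorophenyl and 3-bromophenyl would separate these readings, and a longer chain or an amine on the ring would test how far this position tolerates change.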